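Methyl to phenyl on sulfur across two related cores

The source may hold more compounds than are shown below. What is called first, only, known or untested is meant among the compounds shown, and "the series" means these compounds.

Measured so far in a functional assay on BXPC-3 cells (Homo sapiens) for antiproliferative activity, read by MTT assay, with a stated time of 24 h; a lower number here means a stronger inhibitor, a higher number a weaker inhibitor:
Compound 1 `CCN(CC)CCNC(=O)c1ccc(C(CC)(CC)c2ccc(OCSC)c(C)c2)n1CC`: 5130 nM
Compound 2 `CCN(CC)CCNC(=O)c1ccc(C(CC)(CC)c2ccc(OCSc3ccccc3)c(C)c2)n1CC`: 5670 nM
Compound 3 `CCN(CC)CCNC(=O)c1cc(C(CC)(CC)c2ccc(OCSC)c(C)c2)cn1CC`: 4110 nM

Compound 1 and compound 2 share one core; compound 3 carries the other. The difference between the two cores is not broken down here. The change from compound 1 to compound 2 is phenyl in place of methyl on a sulfur, and it moved the number a 1.1-fold higher number from compound 1 to compound 2 (0.04 log units; within the scatter). The values of compound 1, compound 2 and compound 3 all lie within the scatter of one another.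

Compound 4 `CCN(CC)CCNC(=O)c1cc(C(CC)(CC)c2ccc(OCSc3ccccc3)c(C)c2)cn1CC` is not yet measured. It differs from compound 3 by phenyl in place of methyl on a sulfur, the same change at the same place as that from compound 1 to compound 2. The step is expected to be a 1.1-fold higher number from compound 3 to compound 4 (0.04 log units; within the scatter), essentially flat, because the earlier step was a 1.1-fold higher number from compound 1 to compound 2 (0.04 log units; within the scatter). Compound 4 is therefore estimated at 4500 nM in this assay, with a likely range from 2200 nM to 9000 nM.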

Compound 4, half-maximal inhibitory concentration: 5370 nM
Estimate against measurement, compound 4: 1.2-fold (0.08 log units) below; the range from low to high includes it.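

In this assay, phenyl in place of methyl on the sulfur gives a 1.3-fold higher number from compound 3 to compound 4 (0.12 log units; within the scatter), so the change is essentially flat on the second core as well. Going by these compounds alone, this shows only that the swap leaves the number within the scatter on these two cores; with no step beyond the scatter, it does not show that a measurable effect carries from one core to another, and it says nothing about further cores. The two steps do not differ: the same change on two cores in this assay, a 1.1-fold higher number (0.04 log units; within the scatter) from compound 1 to compound 2 and a 1.3-fold higher number (0.12 log units; within the scatter) from compound 3 to compound 4, 1.2-fold (0.07 log units) apart, within the scatter of two such steps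

Open, from the compounds shown here alone, is whether another group on the sulfur, such as a longer chain, an amine or a carboxylic acid, would give a step beyond the scatter. Also open, going by these compounds, is whether any such step would hold on both cores.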